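This account rests on a few compounds, and the source may have more. Where it says the series, first, only, none or still open, it means among the compounds named here.

Measured in a functional assay on thoracic aorta (Rattus norvegicus, strain Wistar), with a stated time of 15 min; on this read-out lower numbers stand for an effect already at smaller amounts and higher numbers for an effect only at larger amounts of compound:

compound 1, `COc1ccc(Cl)cc1C(C)NC(=O)NS(=O)(=O)c1ccccc1`: > 300000 nM, which is a limit of the assay rather than a number
compound 2, `COc1ccc(OC)c(CNC(=O)NS(=O)(=O)c2ccc(Cl)cc2)c1`: > 300000 nM, likewise a limit of the assay rather than a number
compound 3, `COc1ccc(Cl)cc1C(C)NC(=O)N(C)S(=O)(=O)c1ccccc1`: 7200 nM

Compound 3 is compound 1 with a single change: methyl in place of hydrogen on an amide-type nitrogen. That change moved the read-out by an at least 41-fold lower number from compound 1 to compound 3 (1.61 log units; beyond the scatter). Because compound 1 rests at the limit of > 300000 nM in this assay, at which 2 of the 3 values shown sit, the true size of this step is known only as a minimum.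

Compound 4, `COc1ccc(OC)c(CNC(=O)N(C)S(=O)(=O)c2ccc(Cl)cc2)c1`, has not yet been measured in this assay. It stands to compound 2 as compound 3 stands to compound 1: methyl in place of hydrogen on an amide-type nitrogen. The place of the change is the same in both pairs, an amide-type nitrogen whose other neighbours are a carbonyl carbon and a sulfonyl sulfur, so this is the same change carried over to a second core. How the core of compound 2 differs from the core of compound 1 is not broken down here.

For compound 4 a step of roughly an at least 12-fold lower number from compound 2 to compound 4 (1.07 log units; beyond the scatter) is expected, because the same change gave an at least 41-fold lower number from compound 1 to compound 3 (1.61 log units; beyond the scatter). Compound 2 sits at a limit, so its starting point is a bound rather than a number, and the expectation for compound 4 is correspondingly wide. Compound 4 is therefore estimated at 25000 nM, with an expected range from 4000 nM to 200000 nM.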

Compound 4, half-maximal effective concentration: 18200 nM
For compound 4 the middle estimate is 1.4-fold (0.14 log units) above the measured one; measured number inside the range.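

In this assay, methyl in place of hydrogen on the amide-type nitrogen again comes with a large change on the second core, an at least 16-fold lower number from compound 2 to compound 4 (1.21 log units; beyond the scatter), so the change carried over to the core of compound 2 in the same direction as on the core of compound 1. Compound 1 and compound 2 each rest at a limit of the assay rather than at a number, which means that each step is known only as a minimum: the limit of > 300000 nM in this assay, at which 2 of the 4 values shown sit. Set side by side, the two steps show that the change is large on both cores, but they do not show whether it is worth the same on each: the same change on two cores in this assay, an at least 41-fold lower number (1.61 log units; beyond the scatter) from compound 1 to compound 3 and an at least 16-fold lower number (1.21 log units; beyond the scatter) from compound 2 to compound 4; the limit leaves it open whether they differ.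

The compounds shown leave open what a longer chain such as ethyl, or a larger group such as benzyl, would do on the same nitrogen. They also leave open the true size of the step from hydrogen to methyl on either core, and whether the step would hold on a third core.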